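This account rests on a few compounds, and the source may have more. Where it says the series, first, only, none or still open, it means among the compounds named here.

Measured compounds in this series:

Compound 1 `CSCc1ccc(Nc2ncc(Cc3c(F)cccc3F)o2)cc1`: in an ADME assay on MT2 cells (Homo sapiens) for cytotoxicity, read by MTT assay (on this read-out higher numbers stand for lower toxicity in this test and lower numbers for higher toxicity in this test), compound 1 gives > 100000 nM, a limit of the assay rather than a number.
Compound 2 `Clc1cccc(Cl)c1Cc1nnc(Nc2ccc(COCc3ccccc3)cc2)o1`: in this assay compound 2 gives 84000 nM.

Compound 1 therefore stands only at the ceiling of what this assay reports: the limit of > 100000 nM in this assay, at which 1 of the 2 values shown sits. Compound 2 carries a numbered value, and the two entries are of different kinds, so no ordering between them is claimed.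

The step under consideration goes from compound 1 to compound 3 `OCCc1ccc(Nc2ncc(Cc3c(F)cccc3F)o2)cc1`, not yet measured in this assay. The change is hydroxymethyl in place of methylsulfanyl on a saturated chain carbon bound to an aromatic carbon.

Going by the values given here, with only a limit at the start, no measured step gives a scale for the move from a methylsulfanyl to a hydroxymethyl. The expectation for this assay is a step of a number no higher from compound 1 to compound 3 (the limit leaves the size open) that stays within the scatter, with compound 3 likely again reported as a limit. Compound 3 is accordingly estimated at 100000 nM, within 50000 nM to 300000 nM.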

Compound 3, half-maximal cytotoxic concentration: 35000 nM
Beside the measured number, compound 3's estimate is 2.9-fold (0.46 log units) above it, and the stated range ends above it.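

In this assay, hydroxymethyl in place of methylsulfanyl on a saturated chain carbon bound to an aromatic carbon gives an at least 2.8-fold lower number from compound 1 to compound 3 (0.45 log units; beyond the scatter). This shows that the group at this place can move the read-out beyond the scatter, with the lower number standing for higher toxicity in this test, on an otherwise unchanged core. Compound 1 enters this step only as a limit of the assay, not a number, and because of that the step has a minimum size but no full size: the limit of > 100000 nM in this assay, at which 1 of the 3 values shown sits.

Going by these compounds alone, the one pair gives a direction for this single change and says nothing about whether it would hold on another core. On these data alone, how an aminomethyl group, a carboxylic acid or a longer chain ending in hydroxyl would read at this place remains open.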